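Changing the amine side chain of compound 1

The source may hold more compounds than are shown below. What is called first, only, known or untested is meant among the compounds shown, and "the series" means these compounds.

In an ADME assay on NCM460 cells (Homo sapiens) for cytotoxicity, read by CCK-8 assay, with a stated time of 48 h (a lower number here means a stronger inhibitor, a higher number a weaker inhibitor), compound 1 `COc1ccc(/C=C\c2cc(OC)c(OC)c(OC)c2)cc1OCc1ccc(CNCCO)cc1` gives 39000 nM and compound 2 `COc1ccc(/C=C\c2cc(OC)c(OC)c(OC)c2)cc1OCc1ccc(CN2CCCCC2C(=O)NCCNC(=O)OC(C)(C)C)cc1` gives 28000 nM so the two stand within the usual scatter of each other. Compound 3 `COc1ccc(/C=C\c2cc(OC)c(OC)c(OC)c2)cc1OCc1ccc(CN2CC[C@@H](C(=O)O)C2)cc1` keeps the core of compound 1 and differs by 3-carboxypyrrolidin-1-yl in place of (2-hydroxyethyl)amino on a saturated chain carbon bound to an aromatic carbon with 3-carboxypyrrolidin-1-yl in place of (2-hydroxyethyl)amino on a saturated chain carbon bound to an aromatic carbon. Within the data shown here, no measured step covers this change. Compound 2 also carries a different group on that carbon and stays at 28000 nM within the scatter of compound 1. The expected 1.0-fold higher number from compound 1 to compound 3 (0.01 log units; within the scatter) in this assay is therefore none beyond the scatter. For compound 3 the estimated value is 40000 nM with an expected range from 15000 nM to 100000 nM around it.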

Compound 3, half-maximal inhibitory concentration: > 50000 nM
Compound 3 ended at the assay's limit; the forecaster's own chance of this, stated with the estimate: 20%; at least 1.2-fold (0.09 log units) between middle value and limit.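

Among these compounds, putting 3-carboxypyrrolidin-1-yl in place of (2-hydroxyethyl)amino gives an at least 1.2-fold higher number from compound 1 to compound 3 (0.10 log units; that floor lies within the scatter), the only measured step on this saturated chain carbon bound to an aromatic carbon. Compound 3 stands at a limit, not at a number, in this assay: the limit of > 50000 nM in this assay, at which 1 of the 3 values shown sits. On these data alone, the change gives no sign of a lower number, but how far the number rises stays unknown.

Whether the carboxylic acid or the pyrrolidine ring accounts for this result stays open. A methyl ester in place of the carboxylic acid, or a plain pyrrolidine without it, would separate the two.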